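This account rests on a few compounds, and the source may have more. Where it says the series, first, only, none or still open, it means among the compounds named here.

Notes on a small antiproliferative series read in a functional assay on cells (Tumor Cell line, Homo sapiens) for antiproliferative activity; a lower number here means a stronger inhibitor of growth, a higher number a weaker inhibitor of growth. Going by the values given here, compound 1 `Cc1cnc2[nH]c(-c3cccc(F)c3)cc(=O)c2c1` gives 50.1 nM in this assay, the lowest of the three numbers measured so far. The nearest measured neighbour is compound 2 `Cc1ccc2c(O)cc(-c3cccc(Cl)c3)nc2n1`, which in this assay gives 170 nM; that gap is beyond the scatter, so compound 1 stands ahead of compound 2 on these numbers. Compound 3 `Cc1cc(C)c2c(O)cc(-c3ccc4ccccc4c3)nc2n1` is the furthest away: in this assay compound 3 gives 13500 nM, well beyond the scatter from compound 1. Among the compounds with values here, compound 2 and compound 3 carry cores that differ from the core of compound 1, and no two measured compounds differ in one place only, so no measured step yet shows how a single change moves the read-out.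

The next compound, compound 4 `Cc1cnc2[nH]c(-c3cccc(Cl)c3)cc(=O)c2c1`, is a one-point variant of compound 1. The change is chloro in place of fluoro on an aromatic carbon. Everything else in the structure is kept. Within the data shown here, with no measured single-point step to lean on, the expectation for this assay is a step of small size, in no firm direction, and not beyond the scatter. The step of a 1.0-fold lower number from compound 1 to compound 4 (0.00 log units; within the scatter) is accordingly expected to stay within the scatter. Compound 4 is estimated to give 50 nM in this assay, with an expected range from 18 nM to 140 nM.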

Compound 4, concentration for 50% growth inhibition: 269 nM
Beside the measured number, compound 4's estimate is 5.4-fold (0.73 log units) below it; measured number above the stated range.
By their numbers in this assay, from the lowest: compound 1; then compounds 2 and 4 (each within the scatter of the next); then compound 3.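

In this assay, going by these compounds alone, chloro in place of fluoro on an aromatic carbon of the six-membered aromatic ring of carbon only, meta to a large group, gives the only single-point step measured (a 5.4-fold higher number from compound 1 to compound 4 (0.73 log units; beyond the scatter)). This position is therefore not indifferent to which halogen it carries: the two groups each count one heavy atom and no hydrogen-bond donors or acceptors, yet the step lies beyond the scatter, with the lower number on the fluoro side on the core of compound 1. Nothing at hand accounts for this step.

From the compounds shown here alone, whether the position favours fluoro only over chloro, or also over other groups, remains open; a single step cannot show how hydrogen, methyl, methoxy, trifluoromethyl, a nitrile or an amine on the same carbon would read out. It also remains open whether the same exchange would move the number in the same direction on the cores of compound 2 and compound 3, as neither has a one-point partner among the compounds shown.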